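Compound 4: changing the ring on the shared core

The source may hold more compounds than are shown below. What is called first, only, known or untested is meant among the compounds shown, and "the series" means these compounds.

Compound 1, `CCCC(=O)Nc1ccc2[nH]cc(C3CCN(C)CC3)c2n1`: 6.9 nM
Compound 2, `CCN1CC=C(c2c[nH]c3ccc(NC(=O)c4ccc(F)cc4)nc23)CC1`: 25 nM
Compound 3, `CCN1CC=C(c2c[nH]c3ccc(NC(C)=O)nc23)CC1`: 21 nM

In an assay for binding affinity to 5-hydroxytryptamine receptor 1F (Homo sapiens), read by radioligand binding (a higher number here means a weaker inhibitor, a lower number a stronger inhibitor), compound 2 stands highest of the three measured numbers. Compound 3 is nearest, with a step of a 1.2-fold lower number from compound 2 to compound 3 (0.08 log units; within the scatter); compound 1 lies furthest, at a lower number beyond the scatter. Compound 4, `CCCN1CCC(c2c[nH]c3ccc(NC(=O)c4ccc(F)cc4)nc23)CC1`, differs from compound 2 by a group of 9 heavy atoms (8 carbon, 1 nitrogen; one six-membered non-aromatic ring with 1 hetero atom) in place of a group of 8 heavy atoms (7 carbon, 1 nitrogen; one six-membered non-aromatic ring with 1 hetero atom), on an aromatic carbon. Among the measured compounds shown here, the only measured step, a 1.2-fold lower number from compound 2 to compound 3 (0.08 log units; within the scatter), alters the amide and says nothing about this ring change. Compound 1, which carries a ring of the same non-aromatic kind, gives 6.9 nM, but it differs in more than one place, so its lower number is a weak guide. A modest downward step is therefore expected, a 1.8-fold lower number from compound 2 to compound 4 (0.25 log units; within the scatter), likely within the scatter. Compound 4 is estimated at 14 nM, between 5 nM and 40 nM.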

Compound 4, inhibition constant: 18 nM
Compound 4: middle estimate off by 1.3-fold (0.11 log units), on the low side; the range from low to high includes it.
By their numbers in this assay, from the lowest: compound 1; then compounds 4, 3 and 2 (each within the scatter of the next).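

In this assay, replacing the group on this aromatic carbon with 1-propylpiperidin-4-yl gives a 1.4-fold lower number from compound 2 to compound 4 (0.14 log units; within the scatter). The ring can therefore lose its double bond outside aromatic rings and gain a propyl chain on its nitrogen with no change beyond the scatter, something the amide step did not address. No measured evidence offers a reason for this result.

On these data alone, both features change together here, so their separate contributions remain unknown. A butyl chain or a benzyl group on the ring nitrogen would show whether larger groups fit as well.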